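The compounds below may be only part of what the source reports. "The series", "measured", "known", "first", "only" and "open" are said of these compounds alone.

Compound 1 `O=C(C1CCC1)N1CC2CC(C1)N2` gives 11000 nM in an assay on SH-EP1 cells for agonist activity at Neuronal acetylcholine receptor; alpha4/beta2 (Homo sapiens), read by FLIPR and calcium flux; on this read-out higher numbers stand for an effect only at larger amounts of compound and lower numbers for an effect already at smaller amounts; compound 2 `O=C([C@H]1C[C@H]1F)N1CC2CC(C1)N2` gives 1500 nM; compound 3 `O=C([C@@H]1C[C@@H]1F)N1CC2CC(C1)N2` gives 370 nM.

Compound 3 stands lowest of the three: a 4.1-fold lower number from compound 2 to compound 3 (0.61 log units; beyond the scatter) and a 30-fold lower number from compound 1 to compound 3 (1.47 log units; beyond the scatter). Compound 4 `C[C@@H]1C[C@@H]1C(=O)N1CC2CC(C1)N2` differs from compound 3 in one place: a group of 4 heavy atoms (4 carbon; one three-membered non-aromatic ring of carbon only) in place of a group of 4 heavy atoms (3 carbon, 1 fluorine; one three-membered non-aromatic ring of carbon only), on a carbonyl carbon. Going by the values given here, no measured step swaps the fluorine of this ring for carbon, so none bears on it directly. The steps of a 7.3-fold lower number from compound 1 to compound 2 (0.87 log units; beyond the scatter) and a 30-fold lower number from compound 1 to compound 3 (1.47 log units; beyond the scatter) show that the group on the carbonyl carbon matters strongly, and a 4.1-fold lower number from compound 2 to compound 3 (0.61 log units; beyond the scatter) shows that even the drawn arrangement of that ring changes the number, in line with the fact that one of compounds 2 and 3 is drawn with a defined configuration and the other without, at the place where they differ. Keeping the ring but replacing fluorine is therefore expected to cost something modest, a 2.4-fold higher number from compound 3 to compound 4 (0.39 log units; beyond the scatter). Compound 4 is estimated at 900 nM, in this assay, with a range from 250 nM to 3500 nM.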

Compound 4, half-maximal effective concentration: 3800 nM
Compound 4: the middle estimate sits 4.2-fold (0.63 log units) below what was measured, and the stated range ends below it.
By their numbers in this assay, from the lowest: compound 3; then compound 2; then compound 4; then compound 1.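

The fluorine of the 2-fluorocyclopropyl group counts for more here than the three-membered ring alone: keeping the ring but putting carbon in its place gives (a 10-fold higher number from compound 3 to compound 4 (1.01 log units; beyond the scatter)), although that all-carbon group still improves on cyclobutyl (a 2.9-fold lower number from compound 1 to compound 4 (0.46 log units; beyond the scatter)). Measured against the other fluorinated compound, methyl in place of fluoro costs less (a 2.5-fold higher number from compound 2 to compound 4 (0.40 log units; beyond the scatter)), so the size of the loss depends on which fluorinated compound is the partner. Nothing shown explains why the loss is this large.

On these data alone, whether a chloro, hydroxyl or amine group on that ring would act more like fluoro or like methyl remains open. So does the effect of a longer chain on the carbonyl carbon.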